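From thiophen-3-yl to 3-(methylcarbamoyl)phenyl on the shared core

This account rests on a few compounds, and the source may have more. Where it says the series, first, only, none or still open, it means among the compounds named here.

Three compounds on this core have entries so far. In a functional assay on EBC-1 cells (Homo sapiens) for antiproliferative activity, with a stated time of 72 h (a lower number here means a stronger inhibitor, a higher number a weaker inhibitor), compound 1 `Cn1cc(-c2cc(Cl)c3ncc(Cc4ccc5ncccc5c4)n3c2)cn1` stands as "not determined" (no result reported). Compound 2 `Fc1cc(-c2cnn(C3CCNCC3)c2)cn2c(Cc3ccc4ncccc4c3)cnc12` gives 1.46 nM. Compound 3 `Fc1cc(-c2ccsc2)cn2c(Cc3ccc4ncccc4c3)cnc12` gives 444 nM, the higher of the two numbers available and beyond the scatter from compound 2.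

Compound 4 `CNC(=O)c1cccc(-c2cc(F)c3ncc(Cc4ccc5ncccc5c4)n3c2)c1` is not yet measured. Its structure departs from compound 3 in one place: 3-(methylcarbamoyl)phenyl in place of thiophen-3-yl on an aromatic carbon. Among the compounds with values here, no measured pair isolates this change, so the judgement rests on little. Compounds 2 and 3 differ only in the group on this same aromatic carbon, and compound 2 at 1.46 nM shows how far the number can fall from that of compound 3. A fall beyond the scatter is expected, a 7.4-fold lower number from compound 3 to compound 4 (0.87 log units; beyond the scatter). Reaching the level of compound 2 is not expected, with a single such number to go on. For compound 4 the estimated value is 60 nM, with an expected range of 10 nM to 400 nM.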

Compound 4, half-maximal inhibitory concentration: 400 nM
Compound 4: middle estimate off by 6.7-fold (0.82 log units), on the low side, and the stated range covers the measured number.
By their numbers in this assay, from the lowest: compound 2; then compounds 4 and 3 (each within the scatter of the next).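

In this assay, 3-(methylcarbamoyl)phenyl in place of thiophen-3-yl on this aromatic carbon gives a 1.1-fold lower number from compound 3 to compound 4 (0.05 log units; within the scatter). At this position, then, the added methylcarbamoyl group and the six-membered aromatic ring of carbon only give a number that cannot be told apart from that of the thiophen-3-yl group, and compound 2 at 1.46 nM still stands well below both compound 3 and compound 4 in the printed values. Nothing available bears on why these two groups give such similar numbers.

Still open, as far as these compounds go, is which part of the group on compound 2 goes with its much lower number. Also open, from the compounds shown here alone, is whether an amine or a carboxylic acid in place of the methylcarbamoyl group on the phenyl ring would move the number away from that of compound 4.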